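The source may hold more compounds than are shown below. What is called first, only, known or untested is meant among the compounds shown, and "the series" means these compounds.

Four compounds share one core and differ only in what hangs from it. Compound 1 `COc1ccc(Cn2c(C(=O)O)c(CNCc3cccc(OC)c3)c3ccccc32)cc1` and compound 3 `COc1cccc(CNCc2c(C(=O)O)n(Cc3ccc(C)cc3)c3cc(C(C)C)ccc23)c1` were tested in a functional assay on Bel-7402 cells (Homo sapiens) for antiproliferative activity, read by MTT assay, with a stated time of 72 h; a higher number here means a weaker inhibitor, a lower number a stronger inhibitor. In this assay compound 1 gives 52900 nM and compound 3 gives 5920 nM. Compound 2 `COc1ccc(Cn2c(C(=O)O)c(CNCc3cc(OC)ccc3O)c3ccc(C)cc32)cc1` reached only a limit of this assay, > 50000 nM. That figure is the limit of > 50000 nM in this assay, at which 1 of the 3 values shown sits. Compound 4 `COc1ccc(Cn2c(C(=O)O)c(CNC(=O)c3cccc(OC)c3)c3ccc(C)cc32)cc1` has not been measured; it differs from compound 2 by (3-methoxyphenyl)carbonyl in place of 2-hydroxy-5-methoxybenzyl on an amine nitrogen. Within the data shown here, no measured pair isolates this change, and compound 1, the nearest measured neighbour, gives 52900 nM in this assay. No gain beyond the scatter is therefore expected; the expected step is an at least 1.2-fold lower number from compound 2 to compound 4 (0.09 log units; that floor lies within the scatter). Compound 4 is expected to give 40000 nM, between 10000 nM and 150000 nM, with a fair chance of another limit.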

Compound 4, half-maximal inhibitory concentration: > 50000 nM
Compound 4: only a limit was reported (the forecaster's own chance of this, stated with the estimate: 45%); middle value at least 1.2-fold (0.09 log units) from the limit.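

Compound 2 and compound 4 both stop at a limit, so no step between them can be read: the limit of > 50000 nM in this assay, at which 2 of the 4 values shown sit.

Going by these compounds, whether (3-methoxyphenyl)carbonyl in place of 2-hydroxy-5-methoxybenzyl on an amine nitrogen changes the result in this assay stays open.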